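The source may hold more compounds than are shown below. What is called first, only, known or untested is meant among the compounds shown, and "the series" means these compounds.

Notes on the series. In a functional assay on HCT-116 cells (Homo sapiens) for antiproliferative activity, read by MTT assay, with a stated time of 72 h (on this read-out higher numbers stand for weaker inhibition and lower numbers for stronger inhibition), compound 1 `N=C(NC(=N)NC1CCCC1)Nc1ccc(C(F)(F)F)cc1` gives 3800 nM and compound 2 `CC(C)NC(=N)NC(=N)Nc1ccc(C(F)(F)F)cc1` gives 4800 nM. Within the data shown here, these two values lie within the scatter of each other, so compound 2 stands level with the only other compound measured so far.

The next compound, compound 3 `CC(C)CNC(=N)NC(=N)Nc1ccc(C(F)(F)F)cc1`, differs from compound 2 in one place: isobutyl in place of isopropyl on an amine nitrogen. In words, this is isobutyl in place of isopropyl on an amine nitrogen.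

Among the measured compounds shown here, one measured step bears on this change, and it also exchanges one alkyl group for another on an amine nitrogen. That step is a 1.3-fold higher number from compound 1 to compound 2 (0.10 log units; within the scatter), with isopropyl in place of cyclopentyl. For the measured compounds named here, a single step sets no trend, and no measured step yet involves isobutyl. Even so, the exchange of cyclopentyl for isopropyl stayed at a 1.3-fold higher number from compound 1 to compound 2 (0.10 log units; within the scatter), so no change beyond the scatter is expected in this assay, in either direction. The expected change is a 1.1-fold lower number from compound 2 to compound 3 (0.03 log units; within the scatter). For compound 3 the estimated value is 4500 nM, with an expected range of 2200 nM to 9000 nM.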

Compound 3, half-maximal inhibitory concentration: 3500 nM
Compound 3: the middle estimate sits 1.3-fold (0.11 log units) above what was measured; the measured number falls inside the stated range.
By their numbers in this assay, from the lowest: compounds 3, 1 and 2 (each within the scatter of the next).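

In this assay, the second exchange at this amine nitrogen also stays within the scatter, with a 1.4-fold lower number from compound 2 to compound 3 (0.14 log units; within the scatter), and the comparison with the ring-bearing compound gives a 1.1-fold lower number from compound 1 to compound 3 (0.04 log units; within the scatter). Across the listed compounds, isobutyl, isopropyl and cyclopentyl therefore cannot be told apart at this place, and the step from isopropylamino to isobutylamino, from 3 to 4 heavy atoms with no ring on either side, leaves the number within the scatter, as the exchange of cyclopentyl for isopropyl already did. No measurement at hand accounts for this level reading or connects it to any property of these groups.

On these data alone, all three groups at this place are plain alkyl groups, so it remains open whether the same level holds for a much longer chain such as octyl, for a phenyl or benzyl group, or for a chain ending in a hydroxyl or an amine. As far as these compounds go, the trifluoromethyl group is common to all three compounds, so it also remains open whether exchanging it for chlorine or a nitrile would move the number beyond the scatter.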